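Triazole aryl swap: chlorophenyl to bromophenyl

The source may report more compounds than this note shows. Statements on the series, on what has been measured and on what is new or still open speak of the compounds shown alone.

Compound 1 `C=C(C)c1cn(-c2cccc(C(=O)/C=C/c3ccc(OC)c(O)c3)c2)nn1`: 7760 nM
Compound 2 `COc1ccc(/C=C/C(=O)c2cccc(-n3cc(-c4cccc(Cl)c4)nn3)c2)cc1O`: 6610 nM

Going by the values given here, in a functional assay on RAW264.7 cells (Mus musculus) for inhibition, with a stated time of 4 days (on this read-out lower numbers stand for stronger inhibition and higher numbers for weaker inhibition), compound 2 gives 6610 nM, the lower of the two numbers so far, with compound 1 nearest. Among the compounds with values here, the single measured step, a 1.2-fold lower number from compound 1 to compound 2 (0.07 log units; within the scatter), lies within the scatter. Compound 3 `COc1ccc(/C=C/C(=O)c2cccc(-n3cc(-c4ccc(Br)cc4)nn3)c2)cc1O` carries the change (4-bromophenyl in place of 3-chlorophenyl on an aromatic carbon). Within the data shown here, no measured step exchanges one halophenyl for another; the only step at this position, 3-chlorophenyl for 1-methylethenyl, stayed within the scatter, so no step beyond the scatter is expected here: a 1.0-fold lower number from compound 2 to compound 3 (0.01 log units; within the scatter). Compound 3 is therefore estimated at 6500 nM, with a range of 3000 nM to 14000 nM.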

Compound 3, half-maximal inhibitory concentration: 6570 nM
Beside the measured number, compound 3's estimate is 1.0-fold (0.00 log units) below it; low and high end bracket the measured number.
By their numbers in this assay, from the lowest: compounds 3, 2 and 1 (each within the scatter of the next).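

In this assay, a step of a 1.0-fold lower number from compound 2 to compound 3 (0.00 log units; within the scatter) shows that 4-bromophenyl can take the place of 3-chlorophenyl on this aromatic carbon without leaving the scatter. The step of a 1.2-fold lower number from compound 1 to compound 3 (0.07 log units; within the scatter) also stays within the scatter, so 1-methylethenyl, 3-chlorophenyl and 4-bromophenyl read alike here. No evidence bears on this result. The swap changes both the halogen and its place on the phenyl ring, so neither can be read alone. On these data alone, whether a carboxylic acid or an amine at this position would give a step beyond the scatter remains open.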